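Removing the cinnamamide: a free aniline on the benzophenone core

The source may report more compounds than this note shows. Statements on the series, on what has been measured and on what is new or still open speak of the compounds shown alone.

Three compounds share a benzophenone core, and all have been read in a functional assay on PC-3 cells (Homo sapiens) for cytotoxicity, read by MTT assay, with a stated time of 72 h; a lower number here means a stronger inhibitor, a higher number a weaker inhibitor. Compound 1, `COc1ccc(C(=O)c2cc(OC)c(OC)c(OC)c2)cc1N`, carries a free amino group and gives 1100 nM. Compound 2, `COc1ccc(/C=C/C(=O)Nc2cc(C(=O)c3cc(OC)c(OC)c(OC)c3)cc(OC)c2OC)cc1`, bears an acylated amine on the other ring and gives 6300 nM; compound 3, `COc1cc(C(=O)c2cc(OC)c(OC)c(OC)c2)cc(NC(=O)/C=C/c2ccc(F)cc2)c1OC`, gives 4100 nM. The step of a 1.5-fold lower number from compound 2 to compound 3 (0.19 log units; within the scatter) swaps fluoro for methoxy. Compound 3 thus stands second highest of the three numbers, nearest to compound 2 and furthest from compound 1.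

Compound 4, `COc1cc(C(=O)c2cc(OC)c(OC)c(OC)c2)cc(N)c1OC`, differs from compound 3 by hydrogen in place of (2-(4-fluorophenyl)ethenyl)carbonyl on a nitrogen on an aromatic ring. Going by the values given here, no measured step covers this change; the one step on record concerns only the aryl substituent of the cinnamoyl group. What does bear on it is compound 1, whose free amino group on this same core gives 1100 nM, a number well below those of the two amides. Compound 4 is therefore expected to move in the same direction, with an estimated step of a 2.3-fold lower number from compound 3 to compound 4 (0.36 log units; beyond the scatter). The estimated value of compound 4 in this assay is 1800 nM, with a range from 600 nM to 6000 nM.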

Compound 4, half-maximal inhibitory concentration: 7400 nM
Beside the measured number, compound 4's estimate is 4.1-fold (0.61 log units) below it; the measured number lies above the stated range.
By their numbers in this assay, from the lowest: compound 1; then compounds 3, 2 and 4 (each within the scatter of the next).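

In this assay, taking the (2-(4-fluorophenyl)ethenyl)carbonyl off the nitrogen gives a 1.8-fold higher number from compound 3 to compound 4 (0.26 log units; within the scatter), and taking off (2-(4-methoxyphenyl)ethenyl)carbonyl gives a 1.2-fold higher number from compound 2 to compound 4 (0.07 log units; within the scatter), so on this core the free amino group cannot be told apart from either amide. Going by these compounds alone, the free amino group alone therefore does not bring the lower number; with the amino group present in both compounds, methoxy in place of hydrogen on an aromatic carbon gives a 6.7-fold higher number from compound 1 to compound 4 (0.83 log units; beyond the scatter), the only new step beyond the scatter. No measurement at hand explains this difference.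

The compounds shown leave open whether a smaller acyl group on this nitrogen, such as acetyl, would read like the free amine or the cinnamamides. They also leave open whether an ethoxy group or a chlorine atom in place of that methoxy would give a number nearer to that of compound 1 or compound 4.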